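Swapping cyclopentyl for ethyl on a weak adenosine binder

The source may hold more compounds than are shown below. What is called first, only, known or untested is meant among the compounds shown, and "the series" means these compounds.

Compound 1 `c1ccc(Cn2nnc3c(NC4CCCC4)nc(-c4ccccc4)nc32)cc1`: 11000000 nM
Compound 2 `Clc1ccccc1Cn1nnc2c(NC3CCCC3)nc(-c3ccccc3)nc21`: 9000000 nM
Compound 3 `FC(F)(F)c1ccccc1Cn1nnc2c(NC3CC3)nc(-c3ccccc3)nc21`: 7800000 nM

For the measured compounds named here, in an assay on isolated protein for binding affinity to adenosine receptor A1 (Bos taurus) (a lower number here means a stronger inhibitor, a higher number a weaker inhibitor), compound 1 gives 11000000 nM, a very weak result, and it stands within the scatter of both other compounds: the one counted step, a 1.2-fold lower number from compound 1 to compound 2 (0.09 log units; within the scatter), is within the scatter, and the values of compound 1 and compound 3 lie no further apart. Compound 4 `CCNc1nc(-c2ccccc2)nc2c1nnn2Cc1ccccc1` differs from compound 1 in one place: ethyl in place of cyclopentyl on a nitrogen on an aromatic ring. Going by the values given here, no measured step touches this change; compound 3 carries a cyclopropyl in that position but also a trifluoromethyl elsewhere, so it cannot be read as a single step. With no guide, and all three numbers alike, no shift beyond the scatter is expected, no change at the digits printed from compound 1 to compound 4 (within the scatter). Compound 4 is therefore estimated at 11000000 nM, with a range from 4000000 nM to 30000000 nM.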

Compound 4, inhibition constant: 91000000 nM
Estimate against measurement, compound 4: 8.3-fold (0.92 log units) below; the whole stated range lies below it.
By their numbers in this assay, from the lowest: compounds 3, 2 and 1 (each within the scatter of the next); then compound 4.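

In this assay the change from cyclopentylamino to ethylamino gives an 8.3-fold higher number from compound 1 to compound 4 (0.92 log units; beyond the scatter) and so makes compound 4 the weaker binder of this pair. For the compounds shown here, this is the first step beyond the scatter, which shows that the group on this nitrogen can shift binding even in a compound that is already very weak. Nothing available explains this shift.

On these data alone, it remains open whether a propyl or butyl chain, or a cyclohexyl ring, would read closer to ethyl or to cyclopentyl. As far as these compounds go, whether the same loss would appear with the chloro group of compound 2 also remains open.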